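Extending the amide substituent: compound 2 to compound 3

The source may report more compounds than this note shows. Statements on the series, on what has been measured and on what is new or still open speak of the compounds shown alone.

Values in a functional assay on HUVEC cells (Homo sapiens) for inhibition, with a stated time of 4 days; a lower number here means a stronger inhibitor, a higher number a weaker inhibitor:
- compound 1 `COc1ccc(C(N)=O)cc1/C=C/c1ccc(Cl)cc1`: 87 nM
- compound 2 `COc1ccc(C(=O)NCCO)cc1/C=C/c1ccc(Cl)cc1`: 910 nM
- compound 3 `COc1ccc(C(=O)NC(CO)CO)cc1/C=C/c1ccc(Cl)cc1`: not yet measured

Going by the values given here, of the two numbers so far, compound 2 has the higher, at 910 nM, and compound 1 is its only neighbour. The next structural change is hydroxymethyl in place of hydrogen on a saturated chain carbon bound to an amide-type nitrogen and a saturated chain carbon. Among the compounds with values here, the one measured step that bears on this is a 10-fold higher number from compound 1 to compound 2 (1.02 log units; beyond the scatter), which comes from 2-hydroxyethyl in place of hydrogen on an amide-type nitrogen. That step is large, and it extends the same amide substituent that changes now. However, it acts at a different place, and a single step establishes no trend, so it offers only an indirect guide. Resting on a 10-fold higher number from compound 1 to compound 2 (1.02 log units; beyond the scatter), a further rise in the number is expected in this assay, though a smaller one. The expected change is a 1.8-fold higher number from compound 2 to compound 3 (0.25 log units; within the scatter). For compound 3 the estimated value is 1600 nM, with an expected range of 600 nM to 4500 nM.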

Compound 3, half-maximal inhibitory concentration in the HUVEC assay: 1500 nM
Beside the measured number, compound 3's estimate is 1.1-fold (0.03 log units) above it; measured number inside the range.
By their numbers in the HUVEC assay, from the lowest: compound 1; then compounds 2 and 3 (each within the scatter of the next).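

In the HUVEC assay, hydroxymethyl on the saturated chain carbon bound to the amide-type nitrogen gives a 1.6-fold higher number from compound 2 to compound 3 (0.22 log units; within the scatter), so this change adds nothing that can be told from the scatter, whereas the complete 2-hydroxy-1-(hydroxymethyl)ethyl group in place of hydrogen on the amide-type nitrogen gives a 17-fold higher number from compound 1 to compound 3 (1.24 log units; beyond the scatter). The large gap to the unsubstituted amide is therefore already present with 2-hydroxyethyl and does not widen measurably at this carbon. In a physicochemical assay for solubility, read by HPLC, in simulated intestinal fluid, with a stated time of 2 h, tested at 10 mM (on this read-out higher numbers stand for higher solubility and lower numbers for lower solubility), compound 2 gives 16 ug/mL and compound 3 gives 251 ug/mL. The same hydroxymethyl does register in the physicochemical assay, which separates the two read-outs at this position, with solubility moving well beyond the scatter while the inhibition number stays within it: the measured solubility of compound 2, 16 ug/mL, and of compound 3, 251 ug/mL, a 16-fold higher number (1.20 log units; beyond the scatter)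

Open, as far as these compounds go, is whether a different group on this chain carbon, such as an amine or a carboxylic acid, would keep the solubility while bringing the number in the HUVEC assay back towards that of compound 1, 87 nM. Also open, from the compounds shown here alone, is how a longer chain carrying the hydroxyl would behave on the amide-type nitrogen, since these few steps set no trend.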